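The compounds below may be only part of what the source reports. "The series", "measured", "known", "first", "only" and "open" are said of these compounds alone.

Compound 1 `S=C(Nc1ccccc1)N1N=C(c2ccc(Cl)cc2)CC1c1ccc2c(c1)OCCO2` gives 187000 nM in a functional assay on HT-29 cells (Homo sapiens) for antiproliferative activity, read by MTT assay, with a stated time of 48 h; a higher number here means a weaker inhibitor of growth, a lower number a stronger inhibitor of growth.
Compound 2 `CSc1ccc(C2=NN(C(=S)Nc3ccccc3)C(c3ccc4c(c3)OCCO4)C2)cc1` reaches only the limit of the assay, > 200000 nM.
Compound 3 `S=C(Nc1ccccc1)N1N=C(c2ccccc2Br)CC1c1ccc2c(c1)OCCO2` likewise reaches only the limit of the assay, > 200000 nM.

All three numbers sit at the weak end of the scale. Compound 3 stands at the limit, so its number is a floor rather than a measured value. Compound 4 `S=C(Nc1ccccc1)N1N=C(c2cccc(Cl)c2)CC1c1ccc2c(c1)OCCO2` differs from compound 3 in one place: 3-chlorophenyl in place of 2-bromophenyl on a carbon with a double bond to nitrogen. Among the compounds with values here, two measured steps bear on this change. The step of an at least 1.0-fold higher number from compound 1 to compound 3 (0.02 log units; that floor lies within the scatter) is itself only a floor, within the scatter. The step that the two limits leave unreadable from compound 2 to compound 3 cannot be read because both ends sit at the limit of > 200000 nM in this assay, at which 2 of the 3 values shown sit. In this assay the step of a number no higher from compound 3 to compound 4 (the limit leaves the size open) is therefore expected to stay within the scatter. Compound 4 is estimated at 200000 nM, between 110000 nM and 400000 nM, with a real chance that only the limit is reported again.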

Compound 4, concentration for 50% growth inhibition: > 200000 nM
Compound 4 gave a limit, no number; the forecaster's own chance of this, stated with the estimate: 60%; the middle value lies on the limit itself.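

Replacing the 4-chlorophenyl of compound 1 with 3-chlorophenyl at this carbon gives, in this assay, an at least 1.0-fold higher number from compound 1 to compound 4 (0.02 log units; that floor lies within the scatter), so this change shows no gain in growth inhibition. Together with compound 2 and compound 3, compound 4 shows that three different aryl groups here all fail to give a measured number. The steps linking compound 4 to compound 2 and compound 3 cannot be read, because both ends of each sit at a limit: the limit of > 200000 nM in this assay, at which 3 of the 4 values shown sit.

The compounds shown leave open whether an amine or a carboxylic acid on this phenyl ring would give a number clear of the limit.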